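Two weak hits and a flexible chain replacing an aryl amine

The source may hold more compounds than are shown below. What is called first, only, known or untested is meant among the compounds shown, and "the series" means these compounds.

Measured so far:
Compound 1, `Nc1ccc(Nc2c(C(=O)NCc3ccc(F)cc3)nc(Br)c3cccnc23)cc1`, in a functional assay on MDA-MB-435 cells (Homo sapiens) for cytotoxicity, read by MTT assay, with a stated time of 72 h (a lower number here means a stronger inhibitor, a higher number a weaker inhibitor), gives 7000 nM.
Compound 2, `N[C@H]1CC[C@H](Nc2c(C(=O)NCc3ccccn3)nc(Br)c3cccnc23)CC1`, gives 4000 nM.

Compound 1 carries the higher of the two numbers, yet its gap to compound 2 lies within the scatter, so neither compound stands apart. Compound 3, `CNCCCNc1c(C(=O)NCc2ccc(F)cc2)nc(Br)c2cccnc12`, has not been measured. It differs from compound 1 in one place: 3-(methylamino)propyl in place of 4-aminophenyl on a nitrogen on an aromatic ring. Among the measured compounds shown here, with no measured step of this kind to lean on, the author expects the step from compound 1 to compound 3, a 1.2-fold lower number from compound 1 to compound 3 (0.07 log units; within the scatter), to stay within the scatter. Compound 3 is therefore estimated at 6000 nM, with a range from 1500 nM to 25000 nM.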

Compound 3, half-maximal inhibitory concentration: 11000 nM
Compound 3: middle estimate off by 1.8-fold (0.26 log units), on the low side; the range from low to high includes it.
By their numbers in this assay, from the lowest: compounds 2, 1 and 3 (each within the scatter of the next, the first and the last beyond it).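

In this assay, 3-(methylamino)propyl in place of 4-aminophenyl gives a 1.6-fold higher number from compound 1 to compound 3 (0.20 log units; within the scatter). On a nitrogen on an aromatic ring, then, an open chain with no ring reads within the scatter of the aryl group, so the aromatic ring of compound 1 is not shown to be needed for this weak level of cytotoxicity. Nothing measured here bears on what lies behind this result. On these data alone, it remains open whether a longer chain, a shorter chain, or a primary amine at the end of the chain would move the number beyond the scatter. Also open, as far as these compounds go, is whether a carboxylic acid at that chain end would do so.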